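The source may hold more compounds than are shown below. What is called first, only, known or untested is meant among the compounds shown, and "the series" means these compounds.

In a functional assay on NUGC-3 cells (Homo sapiens) for inhibition, read by sulforhodamine B assay, with a stated time of 48 h (on this read-out lower numbers stand for stronger inhibition of growth and higher numbers for weaker inhibition of growth), compound 1 `O=C(Nc1ccc(C(F)(F)F)cc1)C1c2ccccc2CCN1C(=O)c1ccc(Cl)cc1` gives 4200 nM. Compound 2 `COc1ccc(NC(=O)C2c3ccccc3CCN2C(=O)c2ccc(Cl)cc2)cc1` gives in this assay a reading of 3630 nM. The two structures differ by trifluoromethyl in place of methoxy on an aromatic carbon, and that change made a 1.2-fold higher number from compound 2 to compound 1 (0.06 log units; within the scatter). Compound 3 `COc1ccccc1NC(=O)C1NCCc2ccccc21` has a different core, and how its core differs from the core of compound 2 is not broken down here. In this assay compound 3 gives only a limit of the assay, > 10000 nM. That reading is the limit of > 10000 nM in this assay, at which 1 of the 3 values shown sits. Compound 4 `O=C(Nc1ccccc1C(F)(F)F)C1NCCc2ccccc21` differs from compound 3 by trifluoromethyl in place of methoxy on an aromatic carbon. Within the data shown here, this is the same kind of change as the one between compound 2 and compound 1, but not the same change: there the trifluoromethyl stands para to a large group, here ortho to a large group. In this assay a step that the limit leaves unreadable from compound 3 to compound 4 is expected, resting on a 1.2-fold higher number from compound 2 to compound 1 (0.06 log units; within the scatter), which stayed within the scatter, and on the starting point being a limit. Compound 4 is therefore expected to give about 15000 nM in this assay, with a range from 7000 nM to 40000 nM, most likely again as a limit.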

Compound 4, concentration for 50% growth inhibition: > 10000 nM
Compound 4 was reported as a limit (the forecaster's own chance of this, stated with the estimate: 70%); the middle value is on the limit's open side.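

Compound 3 and compound 4 both sit at a limit of this assay, so no step between them can be read: the limit of > 10000 nM in this assay, at which 2 of the 4 values shown sit.

The compounds shown leave open whether trifluoromethyl in place of methoxy, ortho to a large group, changes growth inhibition on this core at all, and how far either compound lies beyond that limit.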